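The source may hold more compounds than are shown below. What is called first, only, known or untested is meant among the compounds shown, and "the series" means these compounds.

In an ADME assay on PA-1 cells (Homo sapiens) for cytotoxicity, read by MTT assay, with a stated time of 72 h (a higher number here means a weaker inhibitor, a lower number a stronger inhibitor), compound 1 `COc1ccc(C2=C(c3cc(OC)c(OC)c(OC)c3)C(=O)CC2O[SiH2]C(C)(C)C)cc1OC` gives > 100 ug/mL. This is a limit of the assay, not a number.
Compound 2 `C=CCOc1cc(C2=C(c3cc(OC)c(OC)c(OC)c3)C(=O)C(O)C2)ccc1OC` gives > 100 ug/mL in this assay; this too is a limit, not a number.
Compound 3 `COc1cc(C2=C(c3ccc(OCC(=O)O)cc3)C(O)CC2=O)cc(OC)c1OC` has no result reported in this assay, its entry reading "not determined" (no result reported).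

Compound 1 thus stands only at a limit, where it is joined by the limit of > 100 ug/mL in this assay, at which 2 of the 3 values shown sit, while compound 3 stands without a number at all. Within the data shown here, no two measured compounds differ in a single place, so no measured step is available to guide a prediction.

Compound 4 `COc1cc(C2=C(c3cc(C)c(OC)c(C)c3)C(O[SiH2]C(C)(C)C)CC2=O)cc(OC)c1OC` differs from compound 1 in one place: 4-methoxy-3,5-dimethylphenyl in place of 3,4-dimethoxyphenyl on a double-bonded ring carbon. With nothing measured to lean on, the expected step that the limit leaves unreadable from compound 1 to compound 4 is none beyond the usual scatter. Compound 4 is therefore expected to give about 120 ug/mL in this assay, somewhere between 40 ug/mL and 400 ug/mL, most likely again reported only as a limit.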

Compound 4, half-maximal inhibitory concentration: 32 ug/mL
The estimate for compound 4 lay 3.8-fold (0.57 log units) above the measured number; measured number below the stated range.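

Putting 4-methoxy-3,5-dimethylphenyl in place of 3,4-dimethoxyphenyl on a double-bonded ring carbon gives an at least 3.1-fold lower number from compound 1 to compound 4 (0.49 log units; beyond the scatter) in this assay, so this position can move the read-out. Compound 1 gives > 100 ug/mL, which is a limit, so the full size of the step cannot be read. Without compound 4, the values shown offer no number at all: the limit of > 100 ug/mL in this assay, at which 2 of the 4 values shown sit.

Still open, going by these compounds, is which part of the swap matters, the two methyl groups or the missing methoxy group. Also open, on these data alone, is whether an amine or a chlorine atom on this ring would lower the number further.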